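The compounds below may be only part of what the source reports. "The series", "measured", "known", "first", "only" and "open" are said of these compounds alone.

Compound 2 `CC(C)n1ncc2c(C(=O)NCc3cn(-c4ccccc4F)nn3)cccc21` carries a 2-fluorophenyl group on an aromatic nitrogen. In a functional assay on MCF7 cells (Homo sapiens) for inhibition, read by MTT assay, with a stated time of 72 h (a lower number here means a stronger inhibitor, a higher number a weaker inhibitor), compound 2 gives only a limit, > 40000 nM. Compound 1 `CC(C)n1ncc2c(C(=O)NCc3cn(-c4ccc(I)cc4)nn3)cccc21` likewise gives only a limit, > 40000 nM. Both readings share (the limit of > 40000 nM in this assay, at which 2 of the 2 values shown sit), so the step that the two limits leave unreadable from compound 1 to compound 2 cannot be read; the numbers do not tell whether the two compounds differ at all. Compound 3 `CC(C)n1ncc2c(C(=O)NCc3cn(Cc4ccccc4)nn3)cccc21` has not yet been measured. It differs from compound 2 in one place: benzyl in place of 2-fluorophenyl on an aromatic nitrogen. Within the data shown here, no measured step involves a benzyl group, and the single step available is unreadable, so the numbers in hand give no direction for this change. Compound 3 is therefore expected to remain near the same ceiling, with a step of a number no higher from compound 2 to compound 3 (the limit leaves the size open). The estimate for compound 3 in this assay is 40000 nM, within a range from 15000 nM to 100000 nM.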

Compound 3, half-maximal inhibitory concentration: 9170 nM
Estimate against measurement, compound 3: 4.4-fold (0.64 log units) above; the measured number lies below the stated range.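

The position on the aromatic nitrogen can affect the reading in this assay, since benzyl gives a measurable number where the two groups before it did not, with an at least 4.3-fold lower number from compound 2 to compound 3 (0.63 log units; beyond the scatter) and an at least 4.3-fold lower number from compound 1 to compound 3 (0.63 log units; beyond the scatter). This difference appears even though benzyl and 2-fluorophenyl both have 7 heavy atoms and one six-membered aromatic ring of carbon only, so those counts alone do not separate the compounds. Both steps remain minimum sizes and the step between compounds 1 and 2 cannot be read, as those readings are limits rather than numbers: the limit of > 40000 nM in this assay, at which 2 of the 3 values shown sit.

The compounds shown leave open whether the gain belongs to benzyl itself or simply to the absence of fluorine or iodine. Plain phenyl, 2-fluorobenzyl or a longer chain such as 2-phenylethyl on the same nitrogen would help separate these possibilities.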